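The compounds below may be only part of what the source reports. "The series", "measured", "known", "first", "only" and "open" are said of these compounds alone.

Compound 1 `O=C1NCCN1c1ccc(S(=O)(=O)Nc2cccc(Br)c2)cc1` gives the lowest number of the three measured compounds in a functional assay on M21 cells (Homo sapiens) for antiproliferative activity, read by sulforhodamine B assay, with a stated time of 48 h (a lower number here means a stronger inhibitor, a higher number a weaker inhibitor), at 59 nM. Compound 3 `Cc1cccc(NS(=O)(=O)c2ccc(N3CCNC3=O)cc2)c1C` gives 110 nM, and compound 2 `COc1ccc(NS(=O)(=O)c2ccc(N3CCNC3=O)cc2)cc1` gives 580 nM. Compound 4 `O=C1NCCN1c1ccc(S(=O)(=O)Nc2ccccc2)cc1` differs from compound 1 by hydrogen in place of bromo on an aromatic carbon. Two steps from compound 1 bear on this: a 9.8-fold higher number from compound 1 to compound 2 (0.99 log units; beyond the scatter), while a 1.9-fold higher number from compound 1 to compound 3 (0.27 log units; within the scatter). Both swaps on the sulfonamide nitrogen raised the number, by amounts from within the scatter to modest, so losing the bromo is expected to raise the number somewhat, though a change within the scatter cannot be ruled out. Compound 4 is therefore estimated at 160 nM, with a range of 55 nM to 500 nM, which means an expected step of a 2.7-fold higher number from compound 1 to compound 4 (0.43 log units; beyond the scatter).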

Compound 4, half-maximal inhibitory concentration: 200 nM
Compound 4: middle estimate off by 1.3-fold (0.10 log units), on the low side; the measured number falls inside the stated range.
By their numbers in this assay, from the lowest: compounds 1, 3 and 4 (each within the scatter of the next, the first and the last beyond it); then compound 2.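

In this assay, the bromo is now read on its own: replacing it with hydrogen gives a 3.4-fold higher number from compound 1 to compound 4 (0.53 log units; beyond the scatter), so this change alone accounts for a step beyond the scatter. Removing the two methyl groups gives no readable change, with a 1.8-fold higher number from compound 3 to compound 4 (0.26 log units; within the scatter). Removing the methoxy goes the opposite way from removing the bromo, with a 2.9-fold lower number from compound 2 to compound 4 (0.46 log units; beyond the scatter), so groups on this ring do not all act alike.

From the compounds shown here alone, whether chloro, an amine or a carboxylic acid at the bromo's place would match it remains open. Nothing shown here explains these differences.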